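Amino for chloro on a dichlorinated bicyclic core

The compounds below may be only part of what the source reports. "The series", "measured", "known", "first", "only" and "open" are said of these compounds alone.

Compound 1 `ClCc1ccccc1Cn1cnc2c(Cl)nc(Cl)nc21` gives 6450 nM in a functional assay on MDA-MB-435 cells (Homo sapiens) for cytotoxicity, read by sulforhodamine B assay, with a stated time of 48 h; on this read-out higher numbers stand for lower toxicity in this test and lower numbers for higher toxicity in this test.
Compound 2 `ClCc1cccc(Cn2cnc3c(Cl)nc(Cl)nc32)c1` gives 6310 nM in this assay.
Compound 3 `Nc1nc(Cl)c2ncn(Cc3ccccc3CCl)c2n1` reaches only a limit of this assay, > 100000 nM.

Compound 1 and compound 2 contain the same atoms joined differently; the difference between the two cores is not broken down here, and their two values lie within the scatter of each other. From compound 1 to compound 3 the change is amino in place of chloro on an aromatic carbon, and it brought an at least 15-fold higher number from compound 1 to compound 3 (1.19 log units; beyond the scatter), ending at the limit of > 100000 nM in this assay, at which 1 of the 3 values shown sits. Compound 4 `Nc1nc(Cl)c2ncn(Cc3cccc(CCl)c3)c2n1` awaits measurement; it relates to compound 2 by the same change, (amino in place of chloro on an aromatic carbon), made at a place described in identical words. Compound 4 is expected to show a 24-fold higher number from compound 2 to compound 4 (1.38 log units; beyond the scatter) in this assay, because the same change gave an at least 15-fold higher number from compound 1 to compound 3 (1.19 log units; beyond the scatter). Compound 4 is therefore estimated at 150000 nM, probably reported only as a limit, with an expected range from 40000 nM to 600000 nM.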

Compound 4, concentration lethal to 50% of the cells: 85100 nM
The estimate for compound 4 lay 1.8-fold (0.25 log units) above the measured number; the measured number falls inside the stated range.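

In this assay, amino in place of chloro on an aromatic carbon gives a 13-fold higher number from compound 2 to compound 4 (1.13 log units; beyond the scatter), so the change points the same way on both cores, though two pairs say nothing about any other core in the series. The size of the change cannot be compared closely between the two cores: the same change on two cores in this assay, an at least 15-fold higher number (1.19 log units; beyond the scatter) from compound 1 to compound 3 and a 13-fold higher number (1.13 log units; beyond the scatter) from compound 2 to compound 4; the limit leaves it open whether they differ. The value of compound 3 is a limit: the limit of > 100000 nM in this assay, at which 1 of the 4 values shown sits.

The compounds shown leave open what a methylamino or methoxy group would do in place of that chloro group. They also leave open what amino would do in place of the other chloro group on the core, and what a plain methyl group would do in place of the chloromethyl group.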